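The source may report more compounds than this note shows. Statements on the series, on what has been measured and on what is new or still open speak of the compounds shown alone.

Measured in a functional assay on HOP-62 cells (Homo sapiens) for inhibition, read by sulforhodamine B assay; a lower number here means a stronger inhibitor of growth, a higher number a weaker inhibitor of growth:
- compound 1 `Fc1ccc(-c2ccc(-c3ccc(-c4nc5ccccc5[nH]4)cc3)cc2)cc1`: 39300 nM
- compound 2 `COc1ccc(-c2ccc(-c3ccc(-c4nc5ccccc5[nH]4)cc3)cc2)cc1OC`: 4200 nM
- compound 3 `Oc1cccc2[nH]c(-c3ccc(-c4ccc(-c5ccc(F)cc5)cc4)cc3)nc12`: 8310 nM

Compound 3, at 8310 nM, lies within the scatter of compound 2, at 4200 nM. Both values are clearly lower than that of compound 1, with a 4.7-fold lower number from compound 1 to compound 3 (0.67 log units; beyond the scatter) for the hydroxy addition.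

The next compound is compound 4 `Oc1cccc2[nH]c(-c3ccc(-c4ccc(-c5cccc(Cl)c5)cc4)cc3)nc12`, which carries 3-chlorophenyl in place of 4-fluorophenyl on an aromatic carbon, para to a large group: 3-chlorophenyl in place of 4-fluorophenyl on an aromatic carbon.

Among the measured compounds shown here, the closest precedent is the only measured replacement of the 4-fluorophenyl group, a 9.4-fold lower number from compound 1 to compound 2 (0.97 log units; beyond the scatter), which is modest but beyond the scatter. That step introduced 3,4-dimethoxyphenyl and was taken without the hydroxy group, so it transfers only loosely. The hydroxy step a 4.7-fold lower number from compound 1 to compound 3 (0.67 log units; beyond the scatter) touches another part of the molecule, and compound 4 keeps that hydroxy group, so it sets the starting level and says little about this change. For the measured compounds named here, no chlorophenyl compound has been measured.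

A small move towards a lower number in this assay is therefore expected, probably not clearly beyond the scatter. The expected step is a 1.4-fold lower number from compound 3 to compound 4 (0.14 log units; within the scatter). The estimate for compound 4 is 6000 nM, with an expected range of 2000 nM to 18000 nM.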

Compound 4, concentration for 50% growth inhibition: 2260 nM
Compound 4: middle estimate off by 2.7-fold (0.42 log units), on the high side; measured number inside the range.
By their numbers in this assay, from the lowest: compounds 4, 2 and 3 (each within the scatter of the next, the first and the last beyond it); then compound 1.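

With the hydroxy group kept, replacing only the 4-fluorophenyl group still moves the number in this assay, giving a 3.7-fold lower number from compound 3 to compound 4 (0.57 log units; beyond the scatter). The only earlier replacement of that group, a 9.4-fold lower number from compound 1 to compound 2 (0.97 log units; beyond the scatter), was read without the hydroxy group, so this result adds that the position still responds with the hydroxy group in place. The two groups match in heavy-atom count and neither has hydrogen-bond donors or acceptors, so these counts do not separate them, and no available measurement explains the step.

The halogen and its place on the ring change together in this step, so the compounds shown do not tell whether the lower number belongs to chlorine, to its placement, or to both. From the compounds shown here alone, it also remains open whether the position accepts an amine or a carboxylic acid in place of the halogen, and whether 3-chlorophenyl would lower the number equally in the absence of the hydroxy group.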